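The compounds below may be only part of what the source reports. "The series", "measured", "known", "first", "only" and "open" are said of these compounds alone.

Three compounds have been measured in an assay on HEK293 cells for displacement of a labelled ligand from 5-hydroxytryptamine receptor 6 (Homo sapiens); a lower number here means a stronger inhibitor, a higher number a weaker inhibitor:

compound 1 `O=C1c2ccccc2S(=O)(=O)N1CCCCCN1CCN(c2ccc(Cl)cc2)CC1` gives 703 nM
compound 2 `O=C1c2ccccc2S(=O)(=O)N1CCCCCCN1CCN(c2ncccn2)CC1` gives 5710 nM
compound 3 `O=C1c2ccccc2S(=O)(=O)N1CCCCCCN1CCN(c2ccc(Cl)cc2)CC1` gives 72 nM

Compound 1 stands second highest of the three numbers: compound 2 sits higher and compound 3 lower, both beyond the scatter. Compound 4 `O=C1c2ccccc2S(=O)(=O)N1CCCCCN1CCN(c2cccc(Cl)c2Cl)CC1` differs from compound 1 by 2,3-dichlorophenyl in place of 4-chlorophenyl on an amine nitrogen in a ring. For the measured compounds named here, the only measured step, a 79-fold lower number from compound 2 to compound 3 (1.90 log units; beyond the scatter), concerns a different exchange on that same ring nitrogen and shows the aryl group can matter a great deal, but no measured pair tests a second chlorine on the phenyl ring. Going by the values given here, with no direct precedent, compound 4 is expected to land near compound 1, the estimated step being a 1.4-fold lower number from compound 1 to compound 4 (0.15 log units; within the scatter) in this assay. The estimate for compound 4 is 500 nM, within a range of 100 nM to 2500 nM.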

Compound 4, inhibition constant: 197 nM
Compound 4: middle estimate off by 2.5-fold (0.40 log units), on the high side; the range from low to high includes it.
By their numbers in this assay, from the lowest: compound 3; then compound 4; then compound 1; then compound 2.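

Putting 2,3-dichlorophenyl in place of 4-chlorophenyl on the amine nitrogen gives a 3.6-fold lower number from compound 1 to compound 4 (0.55 log units; beyond the scatter) in this assay. The earlier step, a 79-fold lower number from compound 2 to compound 3 (1.90 log units; beyond the scatter), compared a pyrimidin-2-yl with a 4-chlorophenyl; this pair shows that a change between two chlorophenyl groups also moves the number beyond the scatter, though by a smaller step. No measurement shown here explains this difference.

As far as these compounds go, it remains open whether a methoxyphenyl or fluorophenyl group would serve as well at this nitrogen. From the compounds shown here alone, it also remains open whether the same exchange holds on the longer chain of compound 3.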